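The compounds below may be only part of what the source reports. "The series", "measured", "known", "first", "only" and "open" are said of these compounds alone.

Measured so far in a functional assay on HEK293 cells for activation of 5-hydroxytryptamine receptor 4 (Homo sapiens), read by cAMP accumulation; on this read-out higher numbers stand for larger maximal responses and lower numbers for smaller maximal responses:
compound 1 `COc1cc(N)c(Cl)cc1C(=O)NCC1CCNCC1`: 81%
compound 2 `CCCCCN1CCC(NC(=O)c2cc(Cl)c(N)cc2OC)CC1`: > 100%, a limit of the assay, not a number
compound 3 `COc1cc(N)c(Cl)cc1C(=O)NC1CCN(CCN2CCN(S(C)(=O)=O)CC2)CC1`: 97%

Among the measured compounds shown here, compound 2 stands at the top of this assay: its value > 100% is a limit and not a number, the one value of the three sitting at the limit of > 100% in this assay, at which 1 of the 3 values shown sits. Compound 4 `COc1cc(N)c(Cl)cc1C(=O)NC1CCN(CCCCCN2CCN(S(C)(=O)=O)CC2)CC1` differs from compound 2 by 4-(methylsulfonyl)piperazin-1-yl in place of hydrogen on a saturated chain carbon, five bonds along the chain from an amine nitrogen in a ring. For the measured compounds named here, the one measured step bearing on this change is a number at least 3 percentage points lower from compound 2 to compound 3 (that floor lies within the scatter), where the same group enters, though in place of propyl rather than hydrogen. Compound 3 gives 97% in this assay. The step is therefore expected to be a number no higher from compound 2 to compound 4 (the limit leaves the size open), with no change beyond the scatter. Compound 4 is estimated at 100%, range 85% to 115%.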

Compound 4, intrinsic activity: the largest response reached, in percent of the reference agonist's: > 100%
Compound 4: only a limit was reported; the forecaster's own chance of this, stated with the estimate: 40%; the middle value lies on the limit itself.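

No step can be read from compound 2 to compound 4 in this assay, because both values are limits and not numbers: the limit of > 100% in this assay, at which 2 of the 4 values shown sit.

The compounds shown leave open whether 4-(methylsulfonyl)piperazin-1-yl in place of hydrogen changes the maximal response at all.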